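A few compounds are considered here, and "the series" means these few. Any claim that something is new, unique, unknown or untested is made for them only; others in the source may bear on it.

Of the compounds shown here, three have so far been tested in a functional assay for inhibition of sodium/hydrogen exchanger (Oryctolagus cuniculus); on this read-out lower numbers stand for stronger inhibition and higher numbers for weaker inhibition. Compound 1 `CS(=O)(=O)c1cc(C(=O)N=C(N)N)c(F)cc1F` gives 630 nM. Compound 2 `Cc1c(C(=O)N=C(N)N)cc(S(C)(=O)=O)c(Cl)c1Cl` gives 29 nM, and compound 3 `Cc1cc(-c2ccc(F)cc2)c(S(C)(=O)=O)cc1C(=O)N=C(N)N` gives 36 nM. Compound 3 thus holds the second highest of the three numbers; its nearest neighbour is compound 2, whose number lies within the scatter of its own, while compound 1 is furthest away, well beyond the scatter. Compound 4 `Cc1cc(Oc2ccccc2Cl)c(S(C)(=O)=O)cc1C(=O)N=C(N)N` has not yet been measured. It differs from compound 3 in one place: 2-chlorophenoxy in place of 4-fluorophenyl on an aromatic carbon. For the measured compounds named here, no two measured compounds differ in a single place, so nothing here shows the effect of such a swap directly. I expect a 1.4-fold higher number from compound 3 to compound 4 (0.14 log units; within the scatter) to be small and not beyond the scatter. Compound 4 is therefore expected to give about 50 nM, within a range of 15 nM to 160 nM.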

Compound 4, half-maximal inhibitory concentration: 14 nM
Beside the measured number, compound 4's estimate is 3.6-fold (0.55 log units) above it, and the stated range ends above it.
By their numbers in this assay, from the lowest: compound 4; then compounds 2 and 3 (each within the scatter of the next); then compound 1.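

For the compounds shown here, this is the first change made at a single place: on the aromatic carbon ortho to the methylsulfonyl group, 2-chlorophenoxy in place of 4-fluorophenyl gives a 2.6-fold lower number from compound 3 to compound 4 (0.41 log units; beyond the scatter) in this assay. The position therefore accepts a ring attached through oxygen and carrying chlorine, and inhibition becomes stronger rather than being lost. Nothing available explains this gain.

The linking oxygen and the change of halogen arrive together, so their contributions cannot be separated. On these data alone, whether plain phenoxy or a dimethylamino group would serve as well remains open.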